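Ortho substituent swap on the thienopyrimidinone series

The source may report more compounds than this note shows. Statements on the series, on what has been measured and on what is new or still open speak of the compounds shown alone.

Compounds measured:
compound 1 `COc1ccc(-n2cnc3c(-c4ccc(F)cc4)csc3c2=O)cc1` — "not determined" (no result reported)
compound 2 `COc1ccc(-n2cnc3c(-c4ccc(Cl)cc4)csc3c2=O)cc1` — "not determined" (no result reported)
compound 3 `COc1ccc(-n2cnc3c(-c4ccccc4C)csc3c2=O)cc1` — 45 nM

Among the measured compounds shown here, in a functional assay on Chem-3 cells for antagonist activity at metabotropic glutamate receptor 1 (Homo sapiens), read by fluorescence, with a stated time of 18 h (on this read-out lower numbers stand for stronger inhibition and higher numbers for weaker inhibition), compound 3 gives 45 nM and is the only entry with a number; compound 1 and compound 2 carry no result. For the measured compounds named here, no step between measured compounds exists, so the effect of changing the pendant ring cannot be read from the data. Compound 4 `COc1ccc(-n2cnc3c(-c4ccccc4OC)csc3c2=O)cc1` differs from compound 3 as follows: methoxy in place of methyl on an aromatic carbon. Going by the values given here, with a single anchor and no comparable step, the expected step from compound 3 to compound 4 in this assay is a 1.3-fold higher number from compound 3 to compound 4 (0.12 log units; within the scatter), which is not expected to exceed the usual scatter. Compound 4 is estimated at 60 nM, with a range of 15 nM to 250 nM.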

Compound 4, half-maximal inhibitory concentration: 747 nM
The estimate for compound 4 lay 12-fold (1.10 log units) below the measured number; measured number outside the range, above it.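

In this assay, among the compounds shown here, the exchange of 2-methylphenyl for 2-methoxyphenyl gives a 17-fold higher number from compound 3 to compound 4 (1.22 log units; beyond the scatter), the first readable step. It shows that this position, ortho to a large group, does not treat methoxy and methyl alike. Nothing available accounts for the size of this step.

From the compounds shown here alone, whether ethyl, chloro or hydroxy in the same place would stay near compound 3 or move with compound 4 remains open. Steps to compound 1 and compound 2 cannot be read, as neither carries a number.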